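Tert-butyl in place of methyl on the amide carbonyl

This account rests on a few compounds, and the source may have more. Where it says the series, first, only, none or still open, it means among the compounds named here.

Compound 2 `CC(=O)Nc1cc(Oc2ccc(Nc3nccc4[nH]cc(-c5ccc(F)cc5)c(=O)c34)cc2F)ccn1` gives 36.8% in a functional assay on HT-29 cells (Homo sapiens) for antiproliferative activity, read by MTT assay, with a stated time of 72 h, tested at 10 uM (a lower number here means less inhibition, a higher number more inhibition at the concentration tested (going by the name of the read-out)), the highest of the three measured values. Compound 1 `CCCC(=O)Nc1cc(Oc2ccc(Nc3nccc4[nH]cc(-c5ccc(F)cc5)c(=O)c34)cc2F)ccn1` gives 23.5%, and compound 3 `CC(C)(O)C(=O)Nc1cc(Oc2ccc(Nc3nccc4[nH]cc(-c5ccc(F)cc5)c(=O)c34)cc2F)ccn1` gives -2.9%. Compound 4 `CC(C)(C)C(=O)Nc1cc(Oc2ccc(Nc3nccc4[nH]cc(-c5ccc(F)cc5)c(=O)c34)cc2F)ccn1` differs from compound 2 by tert-butyl in place of methyl on a carbonyl carbon. Among the measured compounds shown here, two measured steps bear on this change: a number 13.3 percentage points higher from compound 1 to compound 2 (beyond the scatter) and a number 39.7 percentage points lower from compound 2 to compound 3 (beyond the scatter). In both, a larger group on the carbonyl carbon went with lower inhibition, though compound 3 also brings a hydroxyl that compound 4 lacks. The expected downward step is therefore a number 21.8 percentage points lower from compound 2 to compound 4 (beyond the scatter). Compound 4 is estimated at 15%, with a likely range from 0% to 30%.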

Compound 4, a percentage reported as inhibition, at one concentration (the size of the read-out at that concentration, not a potency): -45.8%
The estimate for compound 4 lay 60.8 percentage points above the measured number, and the stated range ends above it.
By their numbers in this assay, from the lowest: compound 4; then compound 3; then compound 1; then compound 2.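

With tert-butyl on the carbonyl carbon, the series reaches its lowest number in this assay, the steps being a number 82.6 percentage points lower from compound 2 to compound 4 (beyond the scatter) and a number 69.3 percentage points lower from compound 1 to compound 4 (beyond the scatter) from the methyl and propyl amides. Methyl in place of hydroxy on the branched group gives a number 42.9 percentage points lower from compound 3 to compound 4 (beyond the scatter), so the hydroxy-bearing group stands above tert-butyl rather than accounting for the low end of the series. Nothing available explains these drops. Still open, on these data alone, is how a dimethylamino group or a carboxylic acid on the branched carbon would read here. As far as these compounds go, a cyclopropyl group on the carbonyl carbon also remains untested in these compounds.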